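Ester to amide at the urea terminus of compound 3

The source may report more compounds than this note shows. Statements on the series, on what has been measured and on what is new or still open speak of the compounds shown alone.

Three compounds sharing one core have been run in a functional assay on HEK293 cells for agonist activity at Vasopressin V2 receptor (Homo sapiens), read by a luciferase reporter and cAMP accumulation; on this read-out higher numbers stand for an effect only at larger amounts of compound and lower numbers for an effect already at smaller amounts. Compound 1 `O=C(NCc1ccc(C(=O)N2CCCCc3ccccc32)c(F)c1)Nc1c(F)cccc1F` gives 180 nM. Compound 2 `Cc1cc(C(=O)N2CCCCc3ccccc32)ccc1CNC(=O)Nc1ccccc1` gives 130 nM. Compound 3 `COC(=O)CNC(=O)NCc1ccc(C(=O)N2CCCCc3ccccc32)cc1C` gives 37 nM, the lowest of the three numbers; its nearest neighbour is compound 2 and the most distant is compound 1, and both gaps lie beyond the scatter. Within the data shown here, the only single-point step among the measured compounds is a 3.5-fold lower number from compound 2 to compound 3 (0.55 log units; beyond the scatter), a modest gain at the urea terminus.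

Compound 4 `Cc1cc(C(=O)N2CCCCc3ccccc32)ccc1CNC(=O)NCC(=O)N1CCCCC1` changes compound 3 at exactly that terminus: piperidin-1-yl in place of methoxy on a carbonyl carbon. Among the measured compounds shown here, no measured step touches this carbonyl carbon, so nothing speaks directly to it. The terminus has shown itself sensitive in this assay through the step from compound 2 to compound 3, but the present change keeps the carbonyl and only swaps what sits on it. Compound 4 is therefore expected to stay close to compound 3, with a step of a 1.1-fold higher number from compound 3 to compound 4 (0.03 log units; within the scatter) that is expected to lie within the scatter. The estimate for compound 4 in this assay is 40 nM, with a range from 15 nM to 120 nM.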

Compound 4, half-maximal effective concentration: 150 nM
Beside the measured number, compound 4's estimate is 3.8-fold (0.57 log units) below it, outside the stated range (above it).
By their numbers in this assay, from the lowest: compound 3; then compounds 2, 4 and 1 (each within the scatter of the next).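

Working notes on the terminus: the carbonyl carbon is not a neutral place in this assay. With the carbonyl kept, piperidin-1-yl in place of methoxy gives a 4.1-fold higher number from compound 3 to compound 4 (0.61 log units; beyond the scatter) and so cancels the advantage of compound 3, which shows that the group on the carbonyl matters and not the carbonyl alone. Set against the phenyl terminus, the same group gives a 1.2-fold higher number from compound 2 to compound 4 (0.06 log units; within the scatter) and is not told apart from phenyl, so a carbonyl on this chain does not by itself bring the gain seen with (methoxycarbonyl)methyl; the data at hand offer no explanation for either step.

Whether the ring or the nitrogen of piperidin-1-yl accounts for the step stays open: dimethylamino on the same carbonyl carbon would keep the nitrogen without the ring, and cyclohexyloxy would keep the ring without the nitrogen. Also open, going by these compounds, is how a carboxylic acid at this terminus, or a longer chain in place of (methoxycarbonyl)methyl, would compare with compound 3.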